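Replacing Cyclopropyl with 2-Oxopropyl on the Amide Carbonyl

The source may hold more compounds than are shown below. What is called first, only, known or untested is meant among the compounds shown, and "the series" means these compounds.

Measured so far in a functional assay on Ehrlich cells (Mus musculus) for cytotoxicity, read by trypan blue exclusion, with a stated time of 2 h, tested at 25 ug/mL; a higher number here means a stronger effect of the compound at the concentration tested, a lower number a weaker effect:
Compound 1 `N#CC1=C(NC(=O)C2CC2)N(c2ccc(S(N)(=O)=O)cc2)C2=C(C(=O)CCC2)C1c1ccc(Cl)cc1Cl` gives 40%.
Compound 2 `N#CC1=C(NC(=O)c2ccccc2)N(c2ccc(S(N)(=O)=O)cc2)C2=C(C(=O)CCC2)C1c1ccc(Cl)cc1Cl` gives 60%.
Compound 3 `NC(=O)C1=C(N)N(c2ccc(S(N)(=O)=O)cc2)C2=C(C(=O)CCC2)C1c1ccc(Cl)cc1Cl` gives 30%.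

Compound 1 stands second highest of the three numbers in this assay. Its nearest neighbour is compound 3, whose value lies within the scatter of it, so no order between the two can be claimed. Within the data shown here, compound 2 lies furthest away, and the one measured step that differs in a single place, a number 20 percentage points higher from compound 1 to compound 2 (beyond the scatter), is a modest rise beyond the scatter, brought by phenyl in place of cyclopropyl on a carbonyl carbon.

Compound 4 `CC(=O)CC(=O)NC1=C(C#N)C(c2ccc(Cl)cc2Cl)C2=C(CCCC2=O)N1c1ccc(S(N)(=O)=O)cc1` has not yet been measured. It differs from compound 1 as follows: 2-oxopropyl in place of cyclopropyl on a carbonyl carbon. The step from compound 1 to compound 2 altered the same carbonyl carbon, but it introduced an aromatic ring, whereas 2-oxopropyl brings no ring and one added hydrogen-bond acceptor, so that step is only a loose guide here. Among the measured compounds shown here, no measured step bears directly on this exchange. A step no larger than the scatter, in either direction, is therefore expected, no change at the digits printed from compound 1 to compound 4 (within the scatter). Compound 4 is estimated to give 40% in this assay, with a range from 20% to 60%.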

Compound 4, a percentage reported as activity, at one concentration (the size of the read-out at that concentration, not a potency): 44%
The estimate for compound 4 lay 4 percentage points below the measured number, within the range that was stated.
By their numbers in this assay, from the lowest: compounds 3, 1 and 4 (each within the scatter of the next, the first and the last beyond it); then compound 2.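

In this assay, the open-chain 2-oxopropyl on the carbonyl carbon gives no readable change from cyclopropyl (a number 4 percentage points higher from compound 1 to compound 4 (within the scatter)), so at this position the loss of the three-membered ring together with the gain of a hydrogen-bond acceptor has no effect that can be told from the scatter. Phenyl now stands apart from 2-oxopropyl as well (a number 16 percentage points lower from compound 2 to compound 4 (beyond the scatter)), which shows that the higher number of compound 2 is not shared by either non-aromatic group seen on this carbonyl carbon. Nothing measured explains these steps.

The compounds shown leave open whether the higher number with phenyl needs an aromatic ring at all, which a cyclohexyl group on the same carbonyl carbon would test. They also leave open how a benzyl group or a pyridyl ring would compare there.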